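Compound 1 to compound 4: a side chain added

The source may hold more compounds than are shown below. What is called first, only, known or untested is meant among the compounds shown, and "the series" means these compounds.

For the measured compounds named here, in a functional assay on KB 3-1 cells (Homo sapiens) for antiproliferative activity, read by MTT assay (a higher number here means a weaker inhibitor, a lower number a stronger inhibitor), compound 1 (`C[C@@H]1[C@H]2CC(=O)[C@H](C)[C@H]2C[C@H]1O[Si](c1ccccc1)(c1ccccc1)C(C)(C)C`) gives 15200 nM, the only numerical value so far. Compound 2 (`CCC(=O)O[C@@H]1C[C@@H]2CC3(C[C@@H]2C1)OCC(C)(C)CO3`) reads > 142000 nM, which is a limit. Compound 3 (`C=CC[C@@H]1[C@H]2C=C[C@H](C)[C@H]2C[C@H]1O[Si](c1ccccc1)(c1ccccc1)C(C)(C)C`) reads > 96000 nM, which is also a limit.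

The change to compound 4 (`CC(C)=CC[C@H]1C(=O)C[C@@H]2[C@@H](C)[C@H](O[Si](c3ccccc3)(c3ccccc3)C(C)(C)C)C[C@@H]21`) is 2-methylprop-1-en-1-yl in place of hydrogen on a saturated chain carbon bound to a saturated ring carbon. Cut one bond further out, it reads methyl to 3-methylbut-2-en-1-yl. Going by the values given here, no measured pair isolates this change, so the expectation is loose: a modest weakening in this assay, not a large shift. The estimated step is a 2.3-fold higher number from compound 1 to compound 4 (0.36 log units; beyond the scatter). For compound 4 the expected value is 35000 nM, with an estimated range of 10000 nM to 100000 nM.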

Compound 4, half-maximal inhibitory concentration: 28200 nM
Compound 4: the middle estimate sits 1.2-fold (0.09 log units) above what was measured; the range from low to high includes it.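

In this assay, for the compounds shown here, the one pair differing in a single place gives a 1.9-fold higher number from compound 1 to compound 4 (0.27 log units; within the scatter) and so offers the first direct reading of this position. Placing 2-methylprop-1-en-1-yl on a saturated chain carbon bound to a saturated ring carbon keeps a measurable value, with no shift distinguishable from scatter. Nothing among the data available bears on this step.

Open, on these data alone, is how an amine or a carboxylic acid at this place would read. Also open, as far as these compounds go, is how a longer saturated chain would read there.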